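Adding ethyl to the amine of compound 2

A few compounds are considered here, and "the series" means these few. Any claim that something is new, unique, unknown or untested is made for them only; others in the source may bear on it.

- compound 1 `CCNCC(=O)Nc1cc(OC)ccc1C(=O)c1ccc(OC)c2c1C=CC(C)(C)O2`: 7230 nM
- compound 2 `C=C(c1ccc(OC)cc1NC(=O)CN)c1ccc(OC)c2c1C=CC(C)(C)O2`: 780 nM
- compound 3 `C=C(c1ccc(OC)cc1NC(=O)CNC)c1ccc(OC)c2c1OC(C)(C)C=C2`: 400 nM

In a functional assay on MCF7 cells (Homo sapiens) for antiproliferative activity, read by MTT assay, with a stated time of 48 h (on this read-out lower numbers stand for stronger inhibition and higher numbers for weaker inhibition), compound 2 gives 780 nM, within the scatter of compound 3 and well under compound 1. Compound 4 `C=C(c1ccc(OC)cc1NC(=O)CNCC)c1ccc(OC)c2c1C=CC(C)(C)O2` is compound 2 with ethyl in place of hydrogen on an amine nitrogen. Among the compounds with values here, no measured pair isolates this change. Compound 3, also substituted on that nitrogen, gives 400 nM, though its core is arranged differently. Compound 1, also substituted there, gives 7230 nM, but it differs from compound 2 elsewhere too. The estimated step of a 1.2-fold lower number from compound 2 to compound 4 (0.08 log units; within the scatter) is expected to stay within the scatter. For compound 4 the estimated value is 650 nM, with an expected range from 250 nM to 1800 nM.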

Compound 4, half-maximal inhibitory concentration: 2920 nM
Estimate against measurement, compound 4: 4.5-fold (0.65 log units) below; measured number above the stated range.
By their numbers in this assay, from the lowest: compounds 3 and 2 (each within the scatter of the next); then compound 4; then compound 1.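

In this assay, within the data shown here, the single change at this amine nitrogen gives a 3.7-fold higher number from compound 2 to compound 4 (0.57 log units; beyond the scatter), so on this core ethyl in place of hydrogen carries a modest loss of activity rather than the neutral step the substituted neighbours had suggested. Compound 1 shares the ethyl with compound 4, and the two read apart, compound 4 at 2920 nM and compound 1 at 7230 nM, so ethyl alone does not set the number. The compounds shown leave open whether a propyl, a cyclopropyl or a ring amine at this nitrogen would follow ethyl. No evidence at hand bears on why the number rises.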